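Methoxy in place of chloro on compound 2

The source may report more compounds than this note shows. Statements on the series, on what has been measured and on what is new or still open speak of the compounds shown alone.

Of the compounds shown here, two sharing one core have been measured in an assay on cells for displacement of a labelled ligand from Neuronal acetylcholine receptor; alpha3/beta4 (Homo sapiens); on this read-out lower numbers stand for stronger inhibition and higher numbers for weaker inhibition. Compound 1 `O=C(Nc1ccccc1)c1cncc(N2CC3CC(C2)N3)c1` gives 192 nM. Among the measured compounds shown here, compound 2 `O=C(Nc1cccc(Cl)c1)c1cncc(N2CC3CC(C2)N3)c1`, which carries a chloro on the six-membered aromatic ring of carbon only, gives 59 nM, the lowest of the two numbers, with compound 1 as its only neighbour. For the measured compounds named here, the single measured step, a 3.3-fold lower number from compound 1 to compound 2 (0.51 log units; beyond the scatter), shows what adding the chloro brought. Compound 3 `COc1cccc(NC(=O)c2cncc(N3CC4CC(C3)N4)c2)c1` differs from compound 2 by methoxy in place of chloro on an aromatic carbon. Going by the values given here, no measured step exchanges one substituent for another at this carbon; the step from compound 1 to compound 2 tells only what the chloro contributed, not what a methoxy does in its place. The expectation for compound 3 in this assay is therefore a number between those of compound 1 and compound 2. The expected step is a 1.7-fold higher number from compound 2 to compound 3 (0.23 log units; within the scatter). The estimate for compound 3 is 100 nM, ranging from 40 nM to 300 nM.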

Compound 3, inhibition constant: 265 nM
For compound 3 the middle estimate is 2.7-fold (0.42 log units) below the measured one; the range from low to high includes it.
By their numbers in this assay, from the lowest: compound 2; then compounds 1 and 3 (each within the scatter of the next).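

In this assay this carbon now has its first direct exchange of one substituent for another, and the two groups are not interchangeable: methoxy in place of chloro gives a 4.5-fold higher number from compound 2 to compound 3 (0.65 log units; beyond the scatter) and so loses what the chloro had brought. Against hydrogen, the methoxy gives a 1.4-fold higher number from compound 1 to compound 3 (0.14 log units; within the scatter) and cannot be told apart from it here, so the lower number seen in a 3.3-fold lower number from compound 1 to compound 2 (0.51 log units; beyond the scatter) goes with the chloro and does not extend to the methoxy. Nothing available here explains why these two groups differ.

From the compounds shown here alone, it remains open whether another halogen such as bromo or fluoro would act like the chloro, and whether an amine or a longer chain such as ethoxy would act like the methoxy. The compounds shown also leave open whether the chloro would give a similar step on a different carbon of this ring.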